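This account rests on a few compounds, and the source may have more. Where it says the series, first, only, none or still open, it means among the compounds named here.

Measured compounds:
Compound 1, `CC(C)C/C(=N\C#N)N(C)Cc1ccc(Cl)nc1`, gives 1.75 in a physicochemical assay for lipophilicity, read by HPLC, using the shake flask method; a higher number here means a more lipophilic compound, a lower number a more polar compound.
Compound 2, `CCCCC/C(=N\C#N)N(C)Cc1ccc(Cl)nc1`, gives 2.3 in this assay.
Compound 3, `C/C(=N\C#N)N(Cc1ccccc1)Cc1ccc(Cl)nc1`, gives 2.11 in this assay.

Among these three, compound 3 sits beyond the scatter above compound 1, while its value and that of compound 2 lie within the scatter of each other. Compound 4, `C=CCN(Cc1ccc(Cl)nc1)/C(C)=N/C#N`, has not yet been measured; it differs from compound 3 in one place: vinyl in place of phenyl on a saturated chain carbon bound to an amine nitrogen. Among the compounds with values here, no measured pair shows this very change. Within the data shown here, the only measured step, a number 0.55 log units higher from compound 1 to compound 2 (beyond the scatter), shows a chain gaining carbon raising the value in this assay; the change to compound 4 runs the other way, shedding an aromatic ring of six carbon atoms for a two-carbon vinyl group, so a drop well beyond the scatter is expected. For compound 4 the estimated value in this assay is 1.2, with a likely range from 0.7 to 1.7. This expected change amounts to a number 0.91 log units lower from compound 3 to compound 4 (beyond the scatter).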

Compound 4, partition coefficient: 1.56
The estimate for compound 4 lay 0.36 log units below the measured number; the measured number falls inside the stated range.
By their numbers in this assay, from the lowest: compounds 4 and 1 (each within the scatter of the next); then compounds 3 and 2 (each within the scatter of the next).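

In this assay, within the data shown here, the swap at a saturated chain carbon bound to an amine nitrogen gives a number 0.55 log units lower from compound 3 to compound 4 (beyond the scatter) and so provides the first reading at this place. The earlier step changed a chain on a saturated chain carbon bound to a carbon with a double bond to nitrogen, so it said nothing about this one. Nothing measured here explains the size of this new step.

Phenyl to vinyl removes an aromatic ring, removes heavy atoms and adds a double bond all at once, and the two compounds cannot tell these changes apart. Cyclohexyl or ethyl in the same place would begin to separate them, since cyclohexyl keeps a six-membered ring without aromaticity and ethyl keeps two carbons without the double bond.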